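A few compounds are considered here, and "the series" means these few. Any claim that something is new, unique, unknown or untested is made for them only; others in the source may bear on it.

Compound 1 `COC[C@H](NC(=O)c1cc(C)on1)C(=O)N[C@@H](CC1CCCCC1)C(=O)N[C@@H](CC(C)C)C(=O)[C@@]1(C)CO1` sits lowest of the two numbers in hand: in a functional assay on MES-SA cells (Homo sapiens) for cytotoxicity, read by luminescence and CellTiter-Glo, with a stated time of 72 h (a lower number here means a stronger inhibitor, a higher number a weaker inhibitor), compound 1 gives 353 nM. Compound 2 `COC[C@H](NC(=O)c1cc(C)on1)C(=O)N[C@H](C(=O)N[C@@H](CC(C)C)C(=O)[C@@]1(C)CO1)C(C)C` gives 636 nM in this assay. For compound 3 `Cc1cc(C(=O)N[C@@H](CC(C)C)C(=O)N[C@@H](CCc2ccccc2)C(=O)N[C@@H](CC(C)C)C(=O)[C@@]2(C)CO2)n[nH]1` this assay reports only a limit, > 1000 nM. Going by the values given here, the step of a 1.8-fold higher number from compound 1 to compound 2 (0.26 log units; within the scatter) is the one measured change at this position. Compound 4 `COC[C@H](NC(=O)c1cc(C)on1)C(=O)N[C@@H](C)C(=O)N[C@@H](CC(C)C)C(=O)[C@@]1(C)CO1` carries the change (hydrogen in place of cyclohexyl on a saturated chain carbon, two bonds along the chain from an amide-type nitrogen and a carbonyl carbon); it removes the same group that the step to compound 2 shrank, and cuts one bond deeper. That step already ran toward a higher number, so a further rise is expected for compound 4, of the size a 3.4-fold higher number from compound 1 to compound 4 (0.53 log units; beyond the scatter), possibly past the point where one of three values shown sits (the limit of > 1000 nM in this assay, at which 1 of the 3 values shown sits). Compound 4 is estimated at 1200 nM, expected between 450 nM and 3500 nM.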

Compound 4, half-maximal inhibitory concentration: 276 nM
Compound 4: the middle estimate sits 4.3-fold (0.64 log units) above what was measured; the whole stated range lies above it.
By their numbers in this assay, from the lowest: compounds 4, 1 and 2 (each within the scatter of the next, the first and the last beyond it). At a limit, above all of these: compound 3.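

In this assay the change from cyclohexylmethyl to methyl gives a 1.3-fold lower number from compound 1 to compound 4 (0.11 log units; within the scatter) and so the cyclohexyl ring is not needed at this position to hold the number of compound 1. Methyl in place of isopropyl gives a 2.3-fold lower number from compound 2 to compound 4 (0.36 log units; beyond the scatter) and the number therefore does not follow the size of this group in one direction across compound 1, compound 2 and compound 4. Nothing in hand bears on a cause for this.

Open, from the compounds shown here alone, is how this position responds to a side chain carrying an amine or a carboxylic acid.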